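Acylthiourea Benzazoles Against a Breast Cancer Cell Line

This account rests on a few compounds, and the source may have more. Where it says the series, first, only, none or still open, it means among the compounds named here.

Measured in a functional assay on MDA-MB-231 cells (Homo sapiens) for cytotoxicity, read by WST assay, with a stated time of 48 h; a higher number here means a weaker inhibitor, a lower number a stronger inhibitor:
compound 1 `N#Cc1ccc2[nH]c(-c3cccc(NC(=S)NC(=O)c4ccc5c(c4)OCCO5)c3)nc2c1`: > 10000 nM
compound 2 `COc1ccc(C(=O)NC(=S)Nc2cccc(-c3nc4ccccc4[nH]3)c2)cc1OC`: > 10000 nM
compound 3 `Cc1ccc(-c2nc3ccccc3[nH]2)cc1NC(=S)NC(=O)c1ccccc1`: > 10000 nM

Each of these values is a limit of the assay, not a number. Compound 1 sits at that limit, which is where every value shown sits (the limit of > 10000 nM in this assay, at which 3 of the 3 values shown sit). No number separates compound 1 from compound 2 or compound 3 in this assay.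

Compound 4 `O=C(NC(=S)Nc1cccc(-c2nc3ccccc3s2)c1)c1ccc2c(c1)OCCO2` differs from compound 1 by 1,3-benzothiazol-2-yl in place of 5-cyano-1H-benzimidazol-2-yl on an aromatic carbon. Going by the values given here, no step between measured compounds is known, so no size can be read off; with all values at the limit, the expected step in this assay is none beyond the scatter, with some chance of a measurable number. Compound 4 is estimated at 15000 nM (range 4000 nM to 50000 nM). The expected step is a step that the limit leaves unreadable from compound 1 to compound 4.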

Compound 4, half-maximal inhibitory concentration: > 10000 nM
Compound 4 was reported as a limit; the forecaster's own chance of this, stated with the estimate: 70%; the middle value lies beyond the limit too.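

In this assay, going by these compounds alone, compound 4 gives > 10000 nM, a limit and not a number; compound 1 also stands at a limit, so no step between compound 1 and compound 4 can be read. The compounds shown leave open which change, if any, would give a measurable number in this assay.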